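Fluorophenyl for Fluoropyridyl: Expected Microsomal Half-Life

The source may hold more compounds than are shown below. What is called first, only, known or untested is meant among the compounds shown, and "the series" means these compounds.

Measured compounds:
compound 1 `CS(=O)(=O)Nc1ccc2c(c1)S(=O)(=O)N=C(C1=C(O)C3CCCC3N(Cc3ccc(F)cn3)C1=O)N2`: > 1 h
compound 2 `CS(=O)(=O)Nc1ccc2c(c1)S(=O)(=O)N=C(C1=C(O)[C@H]3CCC[C@H]3N(CC3CC3)C1=O)N2`: > 1 h

Both measured compounds share one core and both were tested in an in vitro ADME assay on microsomes from liver (Homo sapiens) for metabolic stability; on this read-out lower numbers stand for a shorter-lived compound and higher numbers for a longer-lived compound. Compound 1 gives > 1 h, which is a limit of the assay rather than a number. Compound 2 likewise gives > 1 h, again a limit and not a number. Among the compounds with values here, compound 1 therefore stands at the limit, and the one further value shown sits at the same place (the limit of > 1 h in this assay, at which 2 of the 2 values shown sit). Within the data shown here, no step between two measured compounds differing in a single place is available, so the pair of compound 1 and compound 2 shows only that both reach the limit.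

Compound 3 `CS(=O)(=O)Nc1ccc2c(c1)S(=O)(=O)N=C(C1=C(O)C3CCCC3N(Cc3cccc(F)c3)C1=O)N2` has not yet been measured. It differs from compound 1 in one place: 3-fluorophenyl in place of 5-fluoropyridin-2-yl on a saturated chain carbon bound to an amide-type nitrogen in a ring. Among the measured compounds shown here, with no measured step to lean on, the expected change in this assay is none beyond the scatter: a step that the limit leaves unreadable from compound 1 to compound 3. Compound 3 is accordingly estimated at 1.5 h, with a range from 0.7 h to 4 h, and it is expected that the assay will again report only a limit.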

Compound 3, half-life: 0.85 h
For compound 3 the middle estimate is 1.8-fold (0.25 log units) above the measured one; low and high end bracket the measured number.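

In this assay compound 3 gives 0.85 h, the only value among the compounds shown that is a number rather than a limit. Compound 1 stands at > 1 h, which is a limit. On these data alone, at this place, on a saturated chain carbon bound to an amide-type nitrogen in a ring, 3-fluorophenyl in place of 5-fluoropyridin-2-yl therefore gives an at least 1.1-fold lower number from compound 1 to compound 3 (0.07 log units; that floor lies within the scatter), so the printed figure is only a floor, and the full size of the step stays unknown, with the other two compounds still unresolved: the limit of > 1 h in this assay, at which 2 of the 3 values shown sit.

The compounds shown leave open how far compound 1 lies beyond its limit, and so whether the change from (5-fluoropyridin-2-yl)methyl to 3-fluorobenzyl truly shortens the half-life by more than the usual scatter. They also leave open how this position would read with an unsubstituted benzyl or a pyridin-2-ylmethyl without the fluorine, either of which would show whether the fluorine or the ring nitrogen goes with the difference.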